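A few compounds are considered here, and "the series" means these few. Any claim that something is new, unique, unknown or untested is made for them only; others in the source may bear on it.

Measured compounds:
compound 1 `CCC(CC)S(=O)(=O)c1ccc(S(=O)(=O)N2CCC[C@@H](C(=O)N3CCC(F)(F)CC3)C2)cc1` — 13 nM
compound 2 `CCN(CC)S(=O)(=O)c1ccc(S(=O)(=O)N2CCC[C@@H](C(=O)N3CCC(OC)CC3)C2)cc1` — 140 nM
compound 3 `CC(C)S(=O)(=O)c1ccc(S(=O)(=O)N2CCC[C@@H](C(=O)N3CCC(F)(F)CC3)C2)cc1` — 11 nM

In a functional assay on MIA PaCa-2 cells (Homo sapiens) for inhibition, read by MTT assay, with a stated time of 7 days (a higher number here means a weaker inhibitor, a lower number a stronger inhibitor), compound 2 gives 140 nM, the highest number of the three, and the gaps to compound 1 and to compound 3 both lie beyond the usual scatter, so compound 2 is the weakest inhibitor measured so far. For the measured compounds named here, compound 1 and compound 3 differ from compound 2 in two places at once, at the sulfonyl group and at the amide, so their values show only that those two compounds together are stronger, not which change is responsible. Going by the values given here, the single one-place step, a 1.2-fold lower number from compound 1 to compound 3 (0.07 log units; within the scatter), concerns the group on the sulfonyl sulfur and does not touch the amide.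

Compound 4 `CCN(CC)S(=O)(=O)c1ccc(S(=O)(=O)N2CCC[C@@H](C(=O)NC3CCOCC3)C2)cc1` is made from compound 2 by the change ((oxan-4-yl)amino in place of 4-methoxypiperidin-1-yl on a carbonyl carbon). Among the compounds with values here, no measured step bears on this change, so the direction of its effect in this assay is not known from the data. The estimate for compound 4 is therefore centred near the value of compound 2, with a wide range: 250 nM (60 nM to 1200 nM), a step of a 1.8-fold higher number from compound 2 to compound 4 (0.25 log units; within the scatter) that is expected, not measured.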

Compound 4, half-maximal inhibitory concentration: 3770 nM
Beside the measured number, compound 4's estimate is 15-fold (1.18 log units) below it; measured number outside the range, above it.
By their numbers in this assay, from the lowest: compounds 3 and 1 (each within the scatter of the next); then compound 2; then compound 4.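

In this assay, for the compounds shown here, the group on this carbonyl carbon turns out to matter greatly: the change gives a 27-fold higher number from compound 2 to compound 4 (1.43 log units; beyond the scatter), the first measured one-place step at the amide, whereas the earlier one concerned the group on the sulfonyl sulfur. Both groups bring one six-membered non-aromatic ring with one hetero atom and one hydrogen-bond acceptor, but the entering (oxan-4-yl)amino also carries a hydrogen-bond donor, the amide hydrogen, and has one heavy atom fewer. No supporting measurement is available to explain the size of this step.

On these data alone, a methyl group on the amide nitrogen of compound 4 would separate the presence of the amide hydrogen from the other differences, but its effect remains unknown. Also open, as far as these compounds go, is whether a morpholin-4-yl group on this carbonyl carbon would give a value closer to that of compound 2 or compound 4.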